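This account rests on a few compounds, and the source may have more. Where it says the series, first, only, none or still open, it means among the compounds named here.

Measured so far:
compound 1 `Cc1nc(C(=O)Nc2ccc(Cl)c(-c3nnc4c(Cl)cccn34)c2)cs1` — > 100000 nM
compound 2 `O=C(Nc1ccc(Cl)c(-c2nnc3c(Cl)cccn23)c1)c1ccc(C(F)(F)F)cc1F` — > 100000 nM

In a functional assay on MDA-MB-231 cells (Homo sapiens) for antiproliferative activity, read by MTT assay, with stated times of 72 h and 4 h (a lower number here means a stronger inhibitor, a higher number a weaker inhibitor), compound 1 gives only a limit of the assay, > 100000 nM. Compound 2 likewise reaches only a limit, > 100000 nM. Compound 1 therefore stands at the limit itself with no number of its own, (the limit of > 100000 nM in this assay, at which 2 of the 2 values shown sit). Compound 3 `Cc1cc(Cl)ccc1C(=O)Nc1ccc(Cl)c(-c2nnc3c(Cl)cccn23)c1` differs from compound 1 in one place: 4-chloro-2-methylphenyl in place of 2-methyl-1,3-thiazol-4-yl on a carbonyl carbon. Among the measured compounds shown here, no step between measured compounds is known here. Since compound 2 also stops at a limit, no movement beyond the scatter is expected for compound 3. The step of a number no higher from compound 1 to compound 3 (the limit leaves the size open) is the expected one. For compound 3 the estimate is 100000 nM, with range 30000 nM to 300000 nM, most likely again only a limit.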

Compound 3, half-maximal inhibitory concentration: > 100000 nM
Compound 3: no number, only a limit; the forecaster's own chance of this, stated with the estimate: 85%; the middle value sits exactly at the limit.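

In this assay, among the compounds shown here, compound 3 gives only a limit, > 100000 nM and no step from compound 1 to compound 3 can be read. The compounds shown leave open whether any group on the carbonyl carbon gives a number rather than a limit.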